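The source may hold more compounds than are shown below. What is called first, only, known or untested is meant among the compounds shown, and "the series" means these compounds.

Compound 1 `CC(C)N(C)c1ccc2cc(NC(=O)CCc3ccc(C(F)(F)F)cc3)ccc2n1` gives 2 nM in an assay on isolated protein for displacement of a labelled ligand from melanin-concentrating hormone receptor 1 (Homo sapiens); on this read-out higher numbers stand for weaker inhibition and lower numbers for stronger inhibition. Compound 2 `CC1CCCN1c1ccc2cc(NC(=O)CCc3ccc(C(F)(F)F)cc3)ccc2n1`, which carries a 2-methylpyrrolidin-1-yl in place of the isopropyl(methyl)amino on the shared core, gives 5 nM in this assay, and the step of a 2.5-fold higher number from compound 1 to compound 2 (0.40 log units; beyond the scatter) is modest but real. For the measured compounds named here, of the two compounds measured so far, compound 2 has the higher number, so it is the weaker binder of the pair.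

Compound 3 `CC1CCN(c2ccc3cc(NC(=O)CCc4ccc(C(F)(F)F)cc4)ccc3n2)C1` differs from compound 2 only in the position of the methyl on the pyrrolidine ring: 3-methylpyrrolidin-1-yl in place of 2-methylpyrrolidin-1-yl on an aromatic carbon. Going by the values given here, no measured step compares two methyl positions on this ring; the only step available, from compound 1 to compound 2, concerns the whole amine and gives a modest change. A small shift is therefore expected, probably not beyond the scatter, with a 1.2-fold higher number from compound 2 to compound 3 (0.08 log units; within the scatter) as the estimated step. In this assay compound 3 is estimated at 6 nM, within a range from 2 nM to 20 nM.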

Compound 3, half-maximal inhibitory concentration: 2 nM
The estimate for compound 3 lay 3.0-fold (0.48 log units) above the measured number, and the stated range covers the measured number.
By their numbers in this assay, from the lowest: compounds 1 and 3 (each within the scatter of the next); then compound 2.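

Moving one methyl around the pyrrolidine ring, with the same atoms joined differently, has a measurable effect in this assay: the switch to 3-methylpyrrolidin-1-yl gives a 2.5-fold lower number from compound 2 to compound 3 (0.40 log units; beyond the scatter). The earlier pair could not show this, as the whole amine changed there, whereas here the methyl's place on the ring is the only difference. The open-chain isopropyl(methyl)amino and the ring 3-methylpyrrolidin-1-yl also sit level, with no change at the digits printed from compound 1 to compound 3 (within the scatter), so a ring amine at this position need not give a higher number, though nothing available explains the effect of the methyl's place.

Still open, as far as these compounds go, is whether the methyl is needed at all, a question for plain pyrrolidin-1-yl. Also open, from the compounds shown here alone, is how a larger ring, such as piperidin-1-yl, or a longer group, such as 3-ethylpyrrolidin-1-yl, would compare.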